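The source may hold more compounds than are shown below. What is called first, only, known or untested is meant among the compounds shown, and "the series" means these compounds.

Compound 1 `Clc1cccc(-c2cc(-c3ccc(Cl)o3)cc(-c3cccs3)n2)c1`, compound 2 `Cc1ccc(-c2cc(-c3ccc(Cl)o3)cc(-c3cccs3)n2)cc1` and compound 3 `Clc1ccc(-c2cc(-c3ccco3)cc(-c3cccs3)n2)cc1` share a common core and differ in the groups attached to it. In a functional assay on HCT-15 cells (Homo sapiens) for cytotoxicity, in the presence of a further agent that is not named here (on this read-out lower numbers stand for stronger inhibition and higher numbers for weaker inhibition), compound 1 gives 15500 nM. Compound 2 gives 9890 nM in this assay, and the step of a 1.6-fold lower number from compound 1 to compound 2 (0.20 log units; within the scatter) lies within the scatter. Compound 3 gives only > 100000 nM in this assay, which is a limit of the assay and not a number; compound 3 thus stands at the limit of > 100000 nM in this assay, at which 1 of the 3 values shown sits.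

Compound 4 `Clc1ccc(-c2cc(-c3ccc(Cl)o3)cc(-c3cccs3)n2)cc1` differs from compound 3 in one place: chloro in place of hydrogen on an aromatic carbon, which read one bond further out is furan-2-yl to 5-chlorofuran-2-yl. Among the compounds with values here, no measured step covers this change; the only measured step, a 1.6-fold lower number from compound 1 to compound 2 (0.20 log units; within the scatter), concerns a different place on the core. Compound 1 and compound 2 carry 5-chlorofuran-2-yl and give numbers, whereas compound 3 carries furan-2-yl and sits at the limit. Because compound 1 gives 15500 nM and compound 2 gives 9890 nM, compound 4 is expected to give a number in this assay of about 13000 nM, between 4000 nM and 60000 nM. The expected step is an at least 7.6-fold lower number from compound 3 to compound 4 (0.88 log units; beyond the scatter).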

Compound 4, half-maximal inhibitory concentration: 14200 nM
The estimate for compound 4 lay 1.1-fold (0.04 log units) below the measured number; the measured number falls inside the stated range.
By their numbers in this assay, from the lowest: compounds 2, 4 and 1 (each within the scatter of the next). At a limit, above all of these: compound 3.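

In this assay, within the data shown here, the pair of compound 3 and compound 4 isolates this position for the first time: an at least 7.0-fold lower number from compound 3 to compound 4 (0.84 log units; beyond the scatter), with chloro in place of hydrogen on the furan ring as the only difference. Compound 3 is held only at a limit, which is not a number, so this step gives a lower bound on the change and not its full size: the limit of > 100000 nM in this assay, at which 1 of the 4 values shown sits. Changes on the phenyl group, now read with the 5-chlorofuran-2-yl group held fixed, stay small by comparison, with a 1.4-fold higher number from compound 2 to compound 4 (0.16 log units; within the scatter) for chloro in place of methyl and a 1.1-fold lower number from compound 1 to compound 4 (0.04 log units; within the scatter) for 4-chlorophenyl in place of 3-chlorophenyl.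

On these data alone, what a methyl group, a bromo group or an amine would do in place of this chloro stays open. Also open, as far as these compounds go, is whether the step from furan-2-yl to 5-chlorofuran-2-yl would be of similar size with the phenyl groups of compound 1 or compound 2.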